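Clearance step from compound 1 to compound 4

A few compounds are considered here, and "the series" means these few. Any claim that something is new, unique, unknown or untested is made for them only; others in the source may bear on it.

In an ADME assay (liver) for metabolic stability, with Liver microsome (Rattus norvegicus) as the target, using microsomes and NADPH, with a stated time of 30 min, tested at 1 uM (on this read-out higher numbers stand for fast clearance and lower numbers for slow clearance), compound 1 `COCC#Cc1cc(C(O)(C(F)(F)F)C(F)(F)F)cnc1N1CCN(S(=O)(=O)c2ccc(N)nc2)CC1` stands highest of the three measured compounds at 399 mL.min-1.g-1. Compound 2 `Nc1ccc(S(=O)(=O)N2CCN(c3ncc(C(O)(C(F)(F)F)C(F)(F)F)cc3C#CCCO)CC2)cn1` gives 68 mL.min-1.g-1 and compound 3 `Nc1ccc(S(=O)(=O)N2CCN(c3ncc(C(O)(C(F)(F)F)C(F)(F)F)cc3-c3ccoc3)CC2)cn1` gives 57 mL.min-1.g-1. The step between these two is a 1.2-fold lower number from compound 2 to compound 3 (0.08 log units; within the scatter).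

The open question is compound 4 `Cc1csc(-c2cc(C(O)(C(F)(F)F)C(F)(F)F)cnc2N2CCN(S(=O)(=O)c3ccc(N)nc3)CC2)c1`, where 4-methylthiophen-2-yl stands in place of 3-methoxyprop-1-yn-1-yl on an aromatic carbon: 4-methylthiophen-2-yl in place of 3-methoxyprop-1-yn-1-yl on an aromatic carbon.

Among the compounds with values here, the closest precedent is a 7.0-fold lower number from compound 1 to compound 3 (0.85 log units; beyond the scatter), which removes the same 3-methoxyprop-1-yn-1-yl group and puts furan-3-yl on that aromatic carbon. The other step from the top of the series, a 5.9-fold lower number from compound 1 to compound 2 (0.77 log units; beyond the scatter), has a similar size but only exchanges methoxy for hydroxymethyl on the chain, so it bears less directly. Within the data shown here, both measured changes away from compound 1 lower the number, and no measured compound carries a 4-methylthiophen-2-yl group, so the furan-3-yl step is only a rough guide.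

A step in the same downward direction is expected, beyond the scatter but with its size uncertain. The step expected for compound 4 is a 4.4-fold lower number from compound 1 to compound 4 (0.65 log units; beyond the scatter). The estimate for compound 4 is 90 mL.min-1.g-1, with an expected range of 35 mL.min-1.g-1 to 240 mL.min-1.g-1.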

Compound 4, intrinsic clearance in microsomes: 399 mL.min-1.g-1
Compound 4: the middle estimate sits 4.4-fold (0.65 log units) below what was measured; the whole stated range lies below it.
By their numbers in this assay, from the lowest: compounds 3 and 2 (each within the scatter of the next); then compounds 1 and 4 (each within the scatter of the next).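

In this assay, the exchange of 3-methoxyprop-1-yn-1-yl for 4-methylthiophen-2-yl on this aromatic carbon gives no change at the digits printed from compound 1 to compound 4 (within the scatter), so the loss of the 3-methoxyprop-1-yn-1-yl group does not on its own bring the number down. The low number of compound 3 does not carry over to every five-membered aromatic ring at this carbon, as 4-methylthiophen-2-yl in place of furan-3-yl gives a 7.0-fold higher number from compound 3 to compound 4 (0.85 log units; beyond the scatter). The acyclic comparison points the same way, with a 5.9-fold higher number from compound 2 to compound 4 (0.77 log units; beyond the scatter), which leaves compounds 2 and 3, within the scatter of each other, as the low pair and shows that the group on this carbon can move the read-out in either direction.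

The compounds shown do not separate the methyl group, the sulfur atom and the point of attachment of the ring, and an unsubstituted thiophen-2-yl, a thiophen-3-yl or a 4-methylfuran-2-yl group on this carbon would address that question. Nothing available explains why these groups differ in this read-out.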